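Removing the chain fluoro from the ethylamide of the series

The source may report more compounds than this note shows. Statements on the series, on what has been measured and on what is new or still open speak of the compounds shown alone.

Four members of one series share a core; compound 1 `CCOC(=O)/C(F)=C(C)/C=C/C=C(C)/C=C/c1c(C)cc(OC)c(C)c1C`, compound 2 `COc1cc(C)c(/C=C/C(C)=C/C=C(F)/C(C)=C/C(=O)O)c(C)c1C` and compound 3 `CCNC(=O)/C=C(C)/C(F)=C/C=C(C)/C=C/c1c(C)cc(OC)c(C)c1C` have been measured, compound 4 `CCNC(=O)/C=C(C)/C=C/C=C(C)/C=C/c1c(C)cc(OC)c(C)c1C` has not. In a functional assay on the whole organism (strain Hart Swiss) with Mus musculus as the target, with stated times of 5 days and 2 weeks, at a dose of 10 mg/kg by the intraperitoneal route (a higher number here means a stronger effect of the compound at the dose given, a lower number a weaker effect), compound 1 gives 37%, compound 2 gives 80% and compound 3 gives 73%. Compound 3 thus lies within the scatter of compound 2 and beyond the scatter above compound 1.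

Within the data shown here, the one step between compounds differing in a single place, a number 7 percentage points lower from compound 2 to compound 3 (within the scatter), exchanges ethylamino for hydroxy on a carbonyl carbon and stays within the scatter. Compound 4 differs from compound 3 as follows: hydrogen in place of fluoro on a double-bonded chain carbon bound to two double-bonded chain carbons. Among the measured compounds shown here, no measured pair isolates such a fluoro-for-hydrogen exchange, so the step to compound 4 has no direct precedent, and the carbonyl step gives no guidance on it. The expectation for this assay is therefore a step of a number 7 percentage points lower from compound 3 to compound 4 (within the scatter), not beyond the scatter, in either direction. Compound 4 is estimated at 66%, with a range from 42% to 86%.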

Compound 4, a percentage reported as activity, at one dose (the size of the read-out at that dose, not a potency): 23%
Compound 4: middle estimate off by 43 percentage points, on the high side, outside the stated range (below it).
By their numbers in this assay, from the lowest: compound 4; then compound 1; then compounds 3 and 2 (each within the scatter of the next).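

In this assay, among these compounds, hydrogen in place of fluoro at this position gives a large change, a number 50 percentage points lower from compound 3 to compound 4 (beyond the scatter), whereas the only earlier single-place step, at the carbonyl, stayed within the scatter. The double-bonded chain carbon bound to two double-bonded chain carbons is therefore the more sensitive of the two places tested so far, though this rests on a single pair in the ethylamide. The modest step of a number 14 percentage points lower from compound 1 to compound 4 (beyond the scatter) exchanges a whole group on the chain and cannot be assigned to any one part of it, and no measurement here explains either step.

Open, as far as these compounds go, is whether chloro or a nitrile at this position would keep the read-out of compound 3 or follow compound 4. Also open, from the compounds shown here alone, is whether the carboxylic acid of compound 2 would respond to the same exchange as the ethylamide does.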